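The source may hold more compounds than are shown below. What is called first, only, known or untested is meant among the compounds shown, and "the series" means these compounds.

In an in vitro ADME assay on microsomes from liver (Rattus norvegicus) for metabolic stability, read by LC-MS, tested at 1 uM (on this read-out lower numbers stand for slow clearance and higher numbers for fast clearance), three compounds sharing one core have been measured. Compound 1 `CCCS(=O)(=O)c1cccc(C#Cc2cc(Cl)ccc2OCC(=O)O)c1` gives < 10 mL.min-1.g-1 and this is a limit of the assay, not a number. Compound 2 `CCCS(=O)(=O)c1ccc(F)c(C#Cc2cc(Cl)ccc2OCC(=O)O)c1` gives < 10 mL.min-1.g-1 and this is also a limit. Going by the values given here, compound 3 `Cc1ccc(S(=O)(=O)NC(C)C)cc1C#Cc1cc(Cl)ccc1OCC(=O)O` gives 12 mL.min-1.g-1 and so holds the only actual number of the three.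

Compound 4 `Cc1ccc(S(=O)(=O)N(C)CC(C)C)cc1C#Cc1cc(Cl)ccc1OCC(=O)O` has not yet been measured. It carries isobutyl(methyl)amino in place of isopropylamino on a sulfonyl sulfur and the new group has more heavy atoms and no hydrogen-bond donor.

Among the compounds with values here, the only measured step that the two limits leave unreadable from compound 1 to compound 2 puts fluoro in place of hydrogen on an aromatic carbon. It is a different change and offers no size to carry over. Within the data shown here, no measured step touches the sulfonyl sulfur, so the expectation rests on compound 3 at 12 mL.min-1.g-1 and on the larger group alone.

The expected step of a 2.5-fold higher number from compound 3 to compound 4 (0.40 log units; beyond the scatter) is a moderate rise in clearance, held loosely. For compound 4 the estimated value is 30 mL.min-1.g-1 with an expected range from 12 mL.min-1.g-1 to 75 mL.min-1.g-1 in this assay.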

Compound 4, intrinsic clearance in microsomes: 119 mL.min-1.g-1
Compound 4: middle estimate off by 4.0-fold (0.60 log units), on the low side, and the stated range ends below it.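

In this assay, the change on the sulfonyl sulfur gives a 9.9-fold higher number from compound 3 to compound 4 (1.00 log units; beyond the scatter), so clearance clearly depends on what this position carries. The change adds heavy atoms and removes the hydrogen-bond donor at the same time, and this single step cannot separate those two differences. The earlier step, from compound 1 to compound 2, cannot be read, and it says nothing about this position: the limit of < 10 mL.min-1.g-1 in this assay, at which 2 of the 4 values shown sit.

Still open, from the compounds shown here alone, is whether the rise follows the larger chain or the lost hydrogen on nitrogen; isobutylamino, which keeps that hydrogen, and dimethylamino, which lacks it but carries smaller chains, would help to pull these apart. Going by these compounds, how a ring amine such as morpholine would read on the same sulfur also remains open.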